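Notes on a fused bicyclic series: tolerability in HeLa cells

The compounds below may be only part of what the source reports. "The series", "measured", "known", "first", "only" and "open" are said of these compounds alone.

Measured compounds:
Compound 1 `CC(C)(C)n1c(=O)n(Cc2cc3cc(Cl)ccc3n2CCCS(C)(=O)=O)c2cnccc21` reaches only the limit > 50000 nM in an ADME assay on HeLa cells (Homo sapiens) for cytotoxicity, read by ATP content, with a stated time of 3 days; a lower number here means that less compound is tolerated, a higher number that more compound is tolerated.
Compound 2 `N#CCCCn1c(Cn2c(=O)n(-c3ncccn3)c3ccncc32)cc2cc(Cl)ccc21` likewise reaches only the limit > 50000 nM in this assay.

Both results are limits of the assay rather than numbers. Compound 2 therefore stands at the limit of > 50000 nM in this assay, at which 2 of the 2 values shown sit, alongside compound 1; neither compound shows a tolerated concentration below that limit, and no ordering of the two is possible. Within the data shown here, no step between measured compounds is available that would show how a change on the ring nitrogen bearing the large group moves this read-out.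

Compound 3 `COc1ccc(-n2c(=O)n(Cc3cc4cc(Cl)ccc4n3CCCC#N)c3cnccc32)cc1C` differs from compound 2 by 4-methoxy-3-methylphenyl in place of pyrimidin-2-yl on an aromatic nitrogen. Among the measured compounds shown here, with no measured step to rest on, the expectation for a number no higher from compound 2 to compound 3 (the limit leaves the size open) is no movement beyond the scatter, since compound 2 sits at the limit of > 50000 nM in this assay, at which 2 of the 2 values shown sit. Compound 3 is therefore expected at 50000 nM, with a range from 20000 nM to 100000 nM, and most probably reported once more as a limit rather than a number.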

Compound 3, half-maximal cytotoxic concentration: > 50000 nM
Compound 3: only a limit was reported; the forecaster's own chance of this, stated with the estimate: 70%; the middle value lies on the limit itself.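

Compound 3 also reaches only a limit in this assay, > 50000 nM, so the change from compound 2 to compound 3 cannot be read as a step. The compounds shown leave open what concentration each actually tolerates, and whether the groups on the aromatic nitrogen differ at all in this assay: the limit of > 50000 nM in this assay, at which 3 of the 3 values shown sit.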